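The source may report more compounds than this note shows. Statements on the series, on what has been measured and on what is new or still open speak of the compounds shown alone.

Three analogues built on one shared core have been run in an assay on isolated protein for inhibition of histone deacetylase 8 (Homo sapiens), with a stated time of 1 h; a higher number here means a weaker inhibitor, a lower number a stronger inhibitor. Compound 1 `O=C(COc1ccc2cc(/C=C3/SC(=O)NC3=O)ccc2c1)Nc1ccc(Br)cc1` gives 16000 nM. Compound 2 `O=C(COc1ccc2cc(/C=C3/SC(=O)NC3=O)ccc2c1)Nc1ccc(F)cc1` gives 6600 nM, a step recorded as a 2.4-fold lower number from compound 1 to compound 2 (0.38 log units; beyond the scatter). Compound 3 `Cc1cc(NC(=O)COc2ccc3cc(/C=C4/SC(=O)NC4=O)ccc3c2)no1` returns only a limit of this assay, > 50000 nM, not a number. On the numbers shown, compound 3 therefore sits at the weak end of the set: the steps of an at least 3.1-fold higher number from compound 1 to compound 3 (0.49 log units; beyond the scatter) and an at least 7.5-fold higher number from compound 2 to compound 3 (0.87 log units; beyond the scatter) both run toward weaker inhibition, and their true size is known only as a lower bound because of the limit of > 50000 nM in this assay, at which 1 of the 3 values shown sits.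

Compound 4 `O=C(COc1ccc2cc(/C=C3/SC(=O)NC3=O)ccc2c1)Nc1ccc(Cl)c(Cl)c1` is the next compound, and it differs from compound 3 in this way: 3,4-dichlorophenyl in place of 5-methyl-1,2-oxazol-3-yl on an amide-type nitrogen The two steps that bear on this change are the same two, now read in reverse, and each was at least modest. Because compound 1 with 16000 nM and compound 2 with 6600 nM both carry a halogen-bearing phenyl group on the amide-type nitrogen and both return numbers, compound 4 is expected to regain a measurable value, with an estimated step of an at least 4.1-fold lower number from compound 3 to compound 4 (0.61 log units; beyond the scatter). Compound 4 is accordingly estimated at 12000 nM, within a range from 4000 nM to 40000 nM.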

Compound 4, half-maximal inhibitory concentration: > 50000 nM
Compound 4 was reported as a limit; the forecaster's own chance of this, stated with the estimate: 10%; at least 4.1-fold (0.61 log units) between middle value and limit.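

Compound 4 shows that a halogen-bearing phenyl group on the amide-type nitrogen does not by itself give a readable value in this assay, since 3,4-dichlorophenyl returns only a limit, not a number; the link seen in compound 1 and compound 2 does not extend to compound 4. Against those two compounds there is an at least 7.5-fold higher number from compound 2 to compound 4 (0.87 log units; beyond the scatter) and an at least 3.1-fold higher number from compound 1 to compound 4 (0.49 log units; beyond the scatter), while the step between compound 3 and compound 4 cannot be read. Both readable steps are known only as lower bounds because of the assay limit: the limit of > 50000 nM in this assay, at which 2 of the 4 values shown sit.

As far as these compounds go, whether a phenyl group carrying an amine or a carboxylic acid on this nitrogen would return a number remains open. Also open, from the compounds shown here alone, is how far compound 3 and compound 4 differ from each other.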